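The source may report more compounds than this note shows. Statements on the series, on what has been measured and on what is new or still open speak of the compounds shown alone.

Of the compounds shown here, three sharing one core have been tested in an ADME assay on S2 cells (Drosophila melanogaster) for cytotoxicity, read by MTT assay; a lower number here means that less compound is needed, a higher number that more compound is needed for the effect. Compound 1 `CCCCCC[C@H]1C[C@@H](O)[C@@H](O)C1` gives 110000 nM in this assay. Compound 2 `O=C(/C=C/[C@H]1C[C@@H](O)[C@@H](O)C1)Oc1ccccc1` reaches only a limit of this assay, > 200000 nM, so no number is known for it. Compound 3 `O=C(/C=C/[C@H]1C[C@@H](O)[C@@H](O)C1)Nc1ccc(C(F)(F)F)cc1` likewise reaches only a limit of this assay, > 160000 nM. Compound 3 therefore stands at the limit of > 160000 nM in this assay, at which 1 of the 3 values shown sits, and of the three values shown one further value is a limit, at the limit of > 200000 nM in this assay, at which 1 of the 3 values shown sits. Among the measured compounds shown here, no pair of measured compounds differs in a single place, so no measured step is available to guide the next change.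

Compound 4 `CC(C)(C)c1ccc(NC(=O)/C=C/[C@H]2C[C@@H](O)[C@@H](O)C2)cc1` is not yet measured. It differs from compound 3 in one place: tert-butyl in place of trifluoromethyl on an aromatic carbon. Both groups sit on an aromatic carbon of a six-membered aromatic ring of carbon only, and neither adds a hydrogen-bond donor or acceptor or a charge.

The expected step of a number no higher from compound 3 to compound 4 (the limit leaves the size open) is small, within the usual scatter, in either direction. Compound 4 is therefore estimated at 160000 nM, with a range from 60000 nM to 300000 nM, and it may again be reported only as a limit.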

Compound 4, half-maximal effective concentration: > 180000 nM
Compound 4: no number, only a limit; the forecaster's own chance of this, stated with the estimate: 60%; middle value at least 1.1-fold (0.05 log units) from the limit.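

Among the compounds shown here, compound 3 and compound 4 both give only a limit in this assay, not a number, so no step between them can be read. Still open, going by these compounds, is how much of either compound is needed for the effect, and whether tert-butyl in place of trifluoromethyl changes that amount at all.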